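Notes on the aryl substituent series, compounds 1 to 3

The source may hold more compounds than are shown below. What is called first, only, known or untested is meant among the compounds shown, and "the series" means these compounds.

Measured so far:
compound 1 `CCCC(C)n1c(CC)nc2c(-c3ccc(/C(C)=N\OC)cc3Cl)ccnc21`: 2.3 nM
compound 2 `CCCC(C)n1c(CC)nc2c(-c3ccc(C(C)(C)O)cc3Cl)ccnc21`: 24 nM

In an assay for binding affinity to Corticotropin releasing factor receptor (Rattus norvegicus) (a lower number here means a stronger inhibitor, a higher number a weaker inhibitor), compound 1 gives 2.3 nM, while compound 2 gives 24 nM. Among the compounds with values here, compound 2 thus stands highest of the two numbers, and the single measured step, a 10-fold higher number from compound 1 to compound 2 (1.02 log units; beyond the scatter), is beyond the scatter and large.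

Compound 3 `CCCC(C)n1c(CC)nc2c(-c3ccc(C(C)OC)cc3Cl)ccnc21` is not yet measured. It differs from compound 2 in one place: 1-methoxyethyl in place of 1-hydroxy-1-methylethyl on an aromatic carbon. Within the data shown here, the only step that bears on this change is a 10-fold higher number from compound 1 to compound 2 (1.02 log units; beyond the scatter), and it does so indirectly: there the same 1-hydroxy-1-methylethyl group was exchanged for the methoxy-oxime group of compound 1 rather than for 1-methoxyethyl. The change toward compound 3 is smaller in the same sense, moving the group back toward one with no hydrogen-bond donor as in compound 1.

A downward step of moderate size is therefore expected, a 3.0-fold lower number from compound 2 to compound 3 (0.48 log units; beyond the scatter), falling short of a full return to the number of compound 1. For compound 3 the expected value in this assay is 8 nM, with a range of 2.5 nM to 25 nM.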

Compound 3, inhibition constant: 3.5 nM
Estimate against measurement, compound 3: 2.3-fold (0.36 log units) above; measured number inside the range.
By their numbers in this assay, from the lowest: compounds 1 and 3 (each within the scatter of the next); then compound 2.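

Swapping 1-hydroxy-1-methylethyl for 1-methoxyethyl at this position keeps the same atoms, joined differently, yet in this assay it gives a 6.9-fold lower number from compound 2 to compound 3 (0.84 log units; beyond the scatter), a step beyond the scatter; the position therefore responds to how these atoms are arranged and not only to which atoms are present, with the hydrogen-bond donor count going from 1 to 0 and the acceptor count unchanged. Compound 3 also gives a 1.5-fold higher number from compound 1 to compound 3 (0.18 log units; within the scatter), which lies within the scatter, so the smaller group of compound 3, with no nitrogen, cannot be told apart from the group of compound 1 in this assay, and the oxime of compound 1 is not required for a number of this size. No measurement shown here accounts for the step from compound 2 to compound 3, so its origin stays unexplained.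

The step changes the donor count and the arrangement of the carbons together, so the contribution of each remains unseparated; 1-hydroxyethyl and 1-methoxy-1-methylethyl at the same position would pull the two apart. From the compounds shown here alone, how an amine such as 1-aminoethyl, or a longer ether such as 1-ethoxyethyl, would behave here also remains open.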